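Bromo for 1-Methylethenyl on a Thiophene Amine Series

The compounds below may be only part of what the source reports. "The series", "measured", "known", "first", "only" and "open" are said of these compounds alone.

Measured so far:
Compound 1, `C[C@H]1[C@H](NCc2ccsc2)C[C@H]2C[C@@H]1C2(C)C`, gives 50000 nM in an ADME assay on MDCK cells (Canis lupus familiaris) for cytotoxicity, read by microscopy, with a stated time of 48 h; a lower number here means that less compound is tolerated, a higher number that more compound is tolerated.
Compound 2, `C[C@H]1[C@H](NCc2sccc2Br)C[C@H]2C[C@@H]1C2(C)C`, gives 50000 nM in this assay.
Compound 3, `C=C(C)c1csc(CN[C@@H]2C[C@H]3C[C@@H]([C@H]2C)C3(C)C)c1`, gives 25000 nM in this assay.

Compound 3 carries the lowest of the three numbers, yet its gap to compound 1 and its gap to compound 2 both lie within the scatter, so on this read-out the three compounds cannot be told apart. Compound 4, `C[C@H]1[C@H](NCc2cc(Br)cs2)C[C@H]2C[C@@H]1C2(C)C`, differs from compound 3 in one place: bromo in place of 1-methylethenyl on an aromatic carbon. Within the data shown here, one measured step bears on this change: no change at the digits printed from compound 1 to compound 2 (within the scatter), where a bromo group entered a thiophene ring of the same core without shifting the number. Compound 1 and compound 3 also sit within the scatter of each other, so the 1-methylethenyl group has shown no effect that its removal could undo. Compound 4 is therefore expected to fall in with the others, with a step of a 1.6-fold higher number from compound 3 to compound 4 (0.20 log units; within the scatter) that stays within the scatter. Compound 4 is estimated at 40000 nM in this assay, between 20000 nM and 80000 nM.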

Compound 4, minimum cytotoxic concentration: 6250 nM
Compound 4: middle estimate off by 6.4-fold (0.81 log units), on the high side, and the stated range ends above it.
By their numbers in this assay, from the lowest: compound 4; then compounds 3, 1 and 2 (each within the scatter of the next).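

In this assay, exchanging 1-methylethenyl for bromo on this aromatic carbon, two ring bonds from the ring sulfur, is not a neutral change: a 4.0-fold lower number from compound 3 to compound 4 (0.60 log units; beyond the scatter) lies beyond the scatter. Bromo on the ring is therefore not harmless everywhere, since no change at the digits printed from compound 1 to compound 2 (within the scatter) showed no shift with 3-bromothiophen-2-yl, yet 4-bromothiophen-2-yl gives an 8.0-fold lower number from compound 2 to compound 4 (0.90 log units; beyond the scatter) and, in place of thiophen-3-yl, an 8.0-fold lower number from compound 1 to compound 4 (0.90 log units; beyond the scatter) as well. No measurement shown gives a reason for this lower number.

Among these compounds, compound 4 is the only compound that stands apart, so the finding rests on one structure. On these data alone, whether a chloro, methyl or amino group on the same carbon would also lower the number, or whether this is particular to bromo, remains open.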